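Trading a dimethyl ring for a phenyl-bearing ring

A few compounds are considered here, and "the series" means these few. Any claim that something is new, unique, unknown or untested is made for them only; others in the source may bear on it.

In a toxicity assay on HepG2 2.2.15 cells (Homo sapiens) for cytotoxicity, read by CellTiter-Glo (a lower number here means that less compound is tolerated, a higher number that more compound is tolerated), compound 1 `O=C(Nc1cc(F)c(F)c(F)c1)N1Cc2c(-c3ccc(F)cc3F)cnn2CC1C1CC1` gives 32100 nM. Compound 3 `CC1(C)CC(=O)N(c2cnn3c2CN(C(=O)Nc2cc(F)c(F)c(F)c2)C(C2CC2)C3)C1` gives 115000 nM, the higher of the two true numbers in this small set. Compound 2 `N#CC1CC(=O)N(c2cnn3c2CN(C(=O)Nc2cc(F)c(F)c(F)c2)C(C2CC2)C3)C1` reads > 200000 nM, which is a limit of this assay and not a number.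

Compound 4 `O=C1NC(c2ccccc2)CN1c1cnn2c1CN(C(=O)Nc1cc(F)c(F)c(F)c1)C(C1CC1)C2` changes the group on the same aromatic carbon: 2-oxo-4-phenylimidazolidin-1-yl in place of 4,4-dimethyl-2-oxopyrrolidin-1-yl on an aromatic carbon. In words, 2-oxo-4-phenylimidazolidin-1-yl stands in place of 4,4-dimethyl-2-oxopyrrolidin-1-yl, which brings in a six-membered aromatic ring of carbon only.

Among the measured compounds shown here, three measured steps concern this carbon. Replacing 2,4-difluorophenyl with 4,4-dimethyl-2-oxopyrrolidin-1-yl gave a 3.6-fold higher number from compound 1 to compound 3 (0.55 log units; beyond the scatter). Replacing it with 4-cyano-2-oxopyrrolidin-1-yl gave an at least 6.2-fold higher number from compound 1 to compound 2 (0.79 log units; beyond the scatter). Exchanging the two non-aromatic groups gave an at least 1.7-fold lower number from compound 2 to compound 3 (0.24 log units; that floor lies within the scatter).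

Compound 4 keeps a non-aromatic ring on that carbon, as compound 3 does, but also carries an aromatic ring, as compound 1 does. Part of a 3.6-fold higher number from compound 1 to compound 3 (0.55 log units; beyond the scatter) may therefore be given back, though three compounds are thin support for this. The expected change in this assay is a 2.3-fold lower number from compound 3 to compound 4 (0.36 log units; beyond the scatter), a modest fall. For compound 4 the estimated value is 50000 nM, with an expected range of 18000 nM to 140000 nM.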

Compound 4, half-maximal cytotoxic concentration: 38500 nM
Beside the measured number, compound 4's estimate is 1.3-fold (0.11 log units) above it; measured number inside the range.
By their numbers in this assay, from the lowest: compounds 1 and 4 (each within the scatter of the next); then compound 3. At a limit, above all of these: compound 2.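

In this assay, a non-aromatic ring on this carbon does not by itself keep the number high, since a 3.0-fold lower number from compound 3 to compound 4 (0.48 log units; beyond the scatter). Compound 4 also lies level with the biaryl-type compound 1, the difference being within the scatter: a 1.2-fold higher number from compound 1 to compound 4 (0.08 log units; within the scatter); so with a six-membered aromatic ring of carbon only carried further out on the non-aromatic ring, the gain seen with the two simpler rings no longer appears. Compound 2 reads at a limit and not a number, so an at least 5.1-fold lower number from compound 2 to compound 4 (0.71 log units; beyond the scatter) gives only a floor, yet that floor is beyond the scatter: the limit of > 200000 nM in this assay, at which 1 of the 4 values shown sits.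

The step from compound 3 to compound 4 changes several things at once, as the aromatic ring and the hydrogen-bond donor enter while the 4,4-dimethyl pattern leaves, and the compounds shown cannot separate these parts. Going by these compounds, it also remains open whether a plain 2-oxoimidazolidin-1-yl group without the phenyl, or a phenyl carrying an amine or a carboxylic acid, would stay near compound 4 or move towards compound 3.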